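This account rests on a few compounds, and the source may have more. Where it says the series, first, only, none or still open, it means among the compounds named here.

Measured in a functional assay on V79 cells (Cricetulus griseus) for cytotoxicity, read by colony formation; a higher number here means a weaker inhibitor, a lower number a stronger inhibitor:
Compound 1 `NC1CCN(c2c(F)cc3c(=O)c(C(=O)O)cn(C4CC4)c3c2C(F)(F)F)C1`: 300 ug/mL; 300 ug/mL; 300 ug/mL (3 entries)
Compound 2 `Cc1c(F)c(N2CCC(N)C2)cc2c1c(=O)c(C(=O)O)cn2C1CC1`: 14 ug/mL
Compound 3 `NC1CCN(c2c(F)c(F)c3c(=O)c(C(=O)O)cn(C4CC4)c3c2C(F)(F)F)C1`: 190 ug/mL

Compound 3, at 190 ug/mL, holds the higher of the two single numbers in this assay. The nearest of these belongs to compound 2, at 14 ug/mL, and the gap between the two lies beyond the scatter. Compound 1 has repeated entries rather than a single number, each of them 300 ug/mL; 300 ug/mL; 300 ug/mL (3 entries).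

Compound 4 `Cc1c(F)c(N2CCC(N)C2)c(C(F)(F)F)c2c1c(=O)c(C(=O)O)cn2C1CC1` follows from compound 3 by one change, methyl in place of fluoro on an aromatic carbon. Among the compounds with values here, no measured pair differs in one place only, so this change has no direct precedent. The nearest guide is compound 2, which carries a methyl group without a trifluoromethyl group and gives 14 ug/mL. Compound 4 carries both groups, so a moderate shift towards a lower number is expected, possibly beyond the scatter, but not all the way to the value of compound 2. The expected change is a 3.2-fold lower number from compound 3 to compound 4 (0.50 log units; beyond the scatter). For compound 4 the estimated value is 60 ug/mL, with an expected range from 20 ug/mL to 190 ug/mL.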

Compound 4, half-maximal inhibitory concentration: 290 ug/mL
The estimate for compound 4 lay 4.8-fold (0.68 log units) below the measured number; the measured number lies above the stated range.
By their numbers in this assay, from the lowest: compound 2; then compounds 3 and 4 (each within the scatter of the next).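

At the aromatic carbon ortho to a fluoro group and para to a trifluoromethyl group, methyl in place of fluoro gives a 1.5-fold higher number from compound 3 to compound 4 (0.18 log units; within the scatter) in this assay, so with the trifluoromethyl group in place these two small substituents cannot be told apart at this position. Within the data shown here, the large difference lies elsewhere: with methyl kept at this carbon, a trifluoromethyl group taking the place of a hydrogen gives a 21-fold higher number from compound 2 to compound 4 (1.32 log units; beyond the scatter), which is the first reading of that one change on its own and shows that the low number of compound 2 does not carry over to compound 4. No measurement bears on the reason for either step.

From the compounds shown here alone, what the same swap of fluoro for methyl does when hydrogen rather than trifluoromethyl occupies the other aromatic carbon remains open, as the step from compound 3 to compound 4 was read only with trifluoromethyl present. Also open, going by these compounds, is whether a chlorine, a methoxy group or an amine at the methyl-bearing carbon, or a nitrile or a chlorine in place of the trifluoromethyl group, would give a number near that of compound 2 or near that of compound 4.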